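Thiophen-2-yl to furan-3-yl on two cores: notes

The compounds below may be only part of what the source reports. "The series", "measured", "known", "first", "only" and "open" are said of these compounds alone.

Measured compounds, all in a functional assay on K562 cells (Homo sapiens), read by MTT assay, with a stated time of 72 h; on this read-out lower numbers stand for stronger inhibition and higher numbers for weaker inhibition:
- compound 1, `COc1nc(N)nc2c1c(-c1cccs1)cn2[C@@H]1O[C@H](CO)[C@@H](O)[C@H]1O`: compound 1 gives > 20000 nM, which is a limit of the assay and not a number.
- compound 2, `COc1nc(N)nc2c1c(-c1ccoc1)cn2[C@@H]1O[C@H](CO)[C@@H](O)[C@H]1O`: compound 2 gives > 20000 nM, again a limit of the assay.
- compound 3, `Nc1nc(N)c2c(-c3cccs3)cn([C@@H]3O[C@H](CO)[C@@H](O)[C@H]3O)c2n1`: compound 3 gives > 20000 nM, also a limit of the assay.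

The change from compound 1 to compound 2 is furan-3-yl in place of thiophen-2-yl on an aromatic carbon. Its step in this assay is a step that the two limits leave unreadable from compound 1 to compound 2. The two cores differ by amino in place of methoxy on an aromatic carbon, and that step is a step that the two limits leave unreadable from compound 1 to compound 3. All three values sit at the same point, as the limit of > 20000 nM in this assay, at which 3 of the 3 values shown sit, shows, so no ordering among compound 1, compound 2 and compound 3 can be read.

Compound 4, `Nc1nc(N)c2c(-c3ccoc3)cn([C@@H]3O[C@H](CO)[C@@H](O)[C@H]3O)c2n1`, is not yet measured. It differs from compound 3 by furan-3-yl in place of thiophen-2-yl on an aromatic carbon. Its place line is the same word for word as that of the change from compound 1 to compound 2, so this is the same change made on the other core.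

For compound 4 in this assay the step from compound 3 is expected to be a step that the limit leaves unreadable from compound 3 to compound 4, resting on the step that the two limits leave unreadable from compound 1 to compound 2 on the first core, where both ends stayed at the limit. Compound 4 is therefore expected to give about 30000 nM, within 15000 nM to 100000 nM, most likely reported only as a limit.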

Compound 4, half-maximal inhibitory concentration: > 20000 nM
Compound 4 was reported as a limit (the forecaster's own chance of this, stated with the estimate: 85%); the middle value is on the limit's open side.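

In this assay compound 4 gives > 20000 nM as a limit of the assay and not a number. No new step can be read among compound 1, compound 2, compound 3 and compound 4, all of which sit at one limit: the limit of > 20000 nM in this assay, at which 4 of the 4 values shown sit.

The compounds shown leave open whether furan-3-yl in place of thiophen-2-yl, or amino in place of methoxy, changes inhibition on either core.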